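The compounds below may be only part of what the source reports. "The series", "measured", "known", "first", "only" and "open" are said of these compounds alone.

Measured in a functional assay on DU-145 cells (Homo sapiens) for inhibition, read by sulforhodamine B assay, with a stated time of 48 h; a higher number here means a weaker inhibitor of growth, a lower number a stronger inhibitor of growth:
- Compound 1 `O=C(Cc1csc2nc(-c3ccc(Br)cc3)cn12)N/N=C/c1ccccc1`: 44700 nM
- Compound 2 `O=C(Cc1csc2nc(-c3ccc(Br)cc3)cn12)N/N=C/c1ccccc1O`: 13800 nM

Compound 2 has the lower of the two numbers. Compound 3 `O=C(Cc1csc2nc(-c3ccc(Br)cc3)cn12)N/N=C/c1ccc(O)cc1` differs from it by 4-hydroxyphenyl in place of 2-hydroxyphenyl on a carbon with a double bond to nitrogen. Among the measured compounds shown here, the only measured step that bears on this is modest, a 3.2-fold lower number from compound 1 to compound 2 (0.51 log units; beyond the scatter), for hydroxy in place of hydrogen on an aromatic carbon. For the measured compounds named here, no measured pair shows what moving the hydroxy does, so only a small change, within the scatter, is expected in this assay. The expected step is a 1.4-fold higher number from compound 2 to compound 3 (0.16 log units; within the scatter). For compound 3 the estimate is 20000 nM, with an expected range from 8000 nM to 45000 nM.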

Compound 3, concentration for total growth inhibition: 87100 nM
Estimate against measurement, compound 3: 4.4-fold (0.64 log units) below, and the stated range ends below it.
By their numbers in this assay, from the lowest: compound 2; then compounds 1 and 3 (each within the scatter of the next).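

In this assay, the place of the hydroxy decides the outcome: 4-hydroxyphenyl in place of 2-hydroxyphenyl on a carbon with a double bond to nitrogen gives a 6.3-fold higher number from compound 2 to compound 3 (0.80 log units; beyond the scatter). Hydroxy in place of hydrogen on an aromatic carbon, as 4-hydroxyphenyl, gives a 1.9-fold higher number from compound 1 to compound 3 (0.29 log units; within the scatter), so the benefit seen with 2-hydroxyphenyl does not carry over to this isomer. Nothing available here explains why the two hydroxyphenyl isomers differ. The compounds shown leave open whether a methoxy or an amine in place of the hydroxy of 2-hydroxyphenyl would keep the number of compound 2.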